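Aryl swap on the triazole nitrogen: compound 2 to compound 3

This account rests on a few compounds, and the source may have more. Where it says the series, first, only, none or still open, it means among the compounds named here.

Measured so far:
compound 1 `CCOc1ccc(-n2nncc2CN2C(=O)C3(C(C#N)=C(N)Oc4c3c3nc5ccccc5nc3c3ccccc43)c3ccccc32)cc1` — 25200 nM
compound 2 `CC(=O)Nc1ccc(-n2nncc2CN2C(=O)C3(C(C#N)=C(N)Oc4c(N)cc5nc6ccccc6nc5c43)c3ccccc32)cc1` — > 50000 nM

In a functional assay on A549 cells (Homo sapiens) for antiproliferative activity, read by MTT assay, with a stated time of 48 h (a higher number here means a weaker inhibitor, a lower number a stronger inhibitor), compound 1 gives 25200 nM. Compound 2 returns only a limit in this assay, > 50000 nM, so its place among the numbers is open-ended. Compound 2 sits at the limit of > 50000 nM in this assay, at which 1 of the 2 values shown sits, which is the weaker end of what the two measurements show. Compound 1 and compound 2 differ in more than one place, so their two values are read together only as a pair, not as a step.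

Compound 3 is `N#CC1=C(N)Oc2c(N)cc3nc4ccccc4nc3c2C12C(=O)N(Cc1cnnn1-c1ccc(Cl)cc1Cl)c1ccccc12`. It keeps the core of compound 2 and differs by 2,4-dichlorophenyl in place of 4-acetamidophenyl on an aromatic nitrogen. For the measured compounds named here, no single-change step is measured, so the size of this change in this assay is unknown; the expectation is a step of no more than the scatter, in either direction, with a fair chance that the limit is reached again. Compound 3 is estimated at 40000 nM, between 15000 nM and 100000 nM, which means an expected step of an at least 1.2-fold lower number from compound 2 to compound 3 (0.09 log units; that floor lies within the scatter).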

Compound 3, half-maximal inhibitory concentration: > 50000 nM
Compound 3: only a limit was reported; the forecaster's own chance of this, stated with the estimate: 40%; at least 1.2-fold (0.09 log units) between middle value and limit.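

Compound 2 and compound 3 both return only a limit, so no step can be read between them: the limit of > 50000 nM in this assay, at which 2 of the 3 values shown sit.

The compounds shown leave open whether 2,4-dichlorophenyl in place of 4-acetamidophenyl on the aromatic nitrogen changes antiproliferative activity at all, and in which direction.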